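The source may report more compounds than this note shows. Statements on the series, on what has been measured and on what is new or still open speak of the compounds shown alone.

Among the compounds with values here, compound 1 `CC1(Sc2ccccc2)C(=O)N(c2ccccc2)c2ncccc21` was run in a functional assay on the whole organism (Pleural cavity) for inhibition, with Rattus norvegicus as the target, at a dose of 25 mg/kg (on this read-out higher numbers stand for more inhibition at the one dose given (going by the name of the read-out) and lower numbers for less inhibition), where compound 1 gives 0%, the lowest of the two numbers so far. Compound 2 `CC1(C)C(=O)N(c2ccccc2Cl)c2ncccc21` gives 14% in this assay, a reading that stands above that of compound 1 by an amount beyond the scatter. Compound 3 `CSC1(C)C(=O)N(c2ccccc2)c2ncccc21` is compound 1 with a single change: methyl in place of phenyl on a sulfur. Within the data shown here, no measured pair shows this change, so the step from compound 1 to compound 3 is expected to be small, a number 5 percentage points higher from compound 1 to compound 3 (within the scatter), not clearly beyond the scatter. Compound 3 is accordingly expected to give 5%, within 0% to 22%.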

Compound 3, a percentage reported as inhibition, in the whole organism at one dose (the size of the read-out at that dose, not a potency): 34%
For compound 3 the middle estimate is 29 percentage points below the measured one; the whole stated range lies below it.
By their numbers in this assay, from the lowest: compound 1; then compound 2; then compound 3.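

The sulfur on the saturated ring carbon proves sensitive to what it carries: in this assay, methyl in place of phenyl gives a number 34 percentage points higher from compound 1 to compound 3 (beyond the scatter). Within the data shown here, the earlier compounds had no pair that isolated this change, so this is the first sign that phenylsulfanyl to methylsulfanyl is a large step on this core. Nothing available accounts for the size of the step.

From the compounds shown here alone, it remains open whether an ethyl group or a longer chain on the sulfur would read like methyl or like phenyl. Also open, going by these compounds, is what an amine on the saturated ring carbon, in place of the sulfur, would give.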